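This account rests on a few compounds, and the source may have more. Where it says the series, first, only, none or still open, it means among the compounds named here.

Compound 1 `O=C(c1ccc2cccc(OCc3ccc(B(O)O)cc3)c2n1)N1CCC(Oc2no[n+]([O-])c2S(=O)(=O)c2ccccc2)CC1` and compound 2 `CC1(C)OB(c2ccc(COc3cccc4ccc(C(=O)N5CCC(Oc6no[n+]([O-])c6S(=O)(=O)c6ccccc6)CC5)nc34)cc2)OC1(C)C` share one core; compound 3 `O=C(NCCCOc1no[n+]([O-])c1S(=O)(=O)c1ccccc1)c1ccc2cccc(OCc3ccc(B(O)O)cc3)c2n1` and compound 4 `CC1(C)OB(c2ccc(COc3cccc4ccc(C(=O)NCCCOc5no[n+]([O-])c5S(=O)(=O)c5ccccc5)nc34)cc2)OC1(C)C` share another, and how the two cores differ is not broken down here. In a functional assay on PANC-1 cells (Homo sapiens) for cytotoxicity, read by MTT assay, with a stated time of 48 h, in the presence of a further agent that is not named here (a higher number here means a weaker inhibitor, a lower number a stronger inhibitor), compound 1 gives 20500 nM and compound 2 gives 38300 nM, so the change a group of 9 heavy atoms (6 carbon, 1 boron, 2 oxygen; one five-membered non-aromatic ring with 3 hetero atoms) in place of a group of 3 heavy atoms (1 boron, 2 oxygen; no ring), on an aromatic carbon made a step of a 1.9-fold higher number from compound 1 to compound 2 (0.27 log units; within the scatter). In this assay compound 3 gives 17600 nM. Compound 4 carries the same change on its core, (a group of 9 heavy atoms (6 carbon, 1 boron, 2 oxygen; one five-membered non-aromatic ring with 3 hetero atoms) in place of a group of 3 heavy atoms (1 boron, 2 oxygen; no ring), on an aromatic carbon), and the place lines of both changes read alike. Because the first change produced a 1.9-fold higher number from compound 1 to compound 2 (0.27 log units; within the scatter), compound 4 is expected to show a step of about a 1.9-fold higher number from compound 3 to compound 4 (0.27 log units; within the scatter) beside it, resting on a single earlier pair only. Compound 4 is therefore estimated at 33000 nM in this assay, between 17000 nM and 65000 nM.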

Compound 4, half-maximal inhibitory concentration: 25300 nM
The estimate for compound 4 lay 1.3-fold (0.12 log units) above the measured number; the range from low to high includes it.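

In this assay, putting the group of 9 heavy atoms in place of the group of 3 heavy atoms on the aromatic carbon made a step of a 1.4-fold higher number from compound 3 to compound 4 (0.16 log units; within the scatter). Set beside the earlier step, the two results do not differ: the same change on two cores in this assay, a 1.9-fold higher number (0.27 log units; within the scatter) from compound 1 to compound 2 and a 1.4-fold higher number (0.16 log units; within the scatter) from compound 3 to compound 4, 1.3-fold (0.11 log units) apart, within the scatter of two such steps. The change therefore carried across these two cores without a step beyond the scatter on either, but this does not show that it has a real effect on the number, nor that it would behave alike on any further core.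

The compounds shown leave open what a carboxylic acid or an amine would give at this place. They also leave open whether a longer chain in the core would alter the step.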